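Series notes: methyl for hydrogen from compound 3 to compound 4

This account rests on a few compounds, and the source may have more. Where it says the series, first, only, none or still open, it means among the compounds named here.

Compound 3 `Cc1ccc(C(=O)CCc2nnc(COc3ccccc3)o2)cc1` gives 25.3% in a functional assay on the whole organism (strain Wistar) for inhibition, with Rattus norvegicus as the target, with stated times of 30 min and 2 h, at a dose of 20 mg/kg by the oral route (a lower number here means less inhibition, a higher number more inhibition at the dose given (going by the name of the read-out)), the lowest of the three numbers in hand. Compound 1 `Cc1ccc(C(=O)CCc2nnc(-c3ccccc3Cl)o2)c(C)c1` gives 33.5%, within the scatter of compound 3, while compound 2 `COc1ccc(-c2nnc(CCC(=O)c3ccc(C)cc3C)o2)cc1` gives 62.7%, beyond the scatter. For the measured compounds named here, the one step recorded, a number 29.2 percentage points higher from compound 1 to compound 2 (beyond the scatter), concerns a different group and does not touch the place changed here. Compound 4 `Cc1ccc(C(=O)CCc2nnc(COc3ccccc3)o2)c(C)c1` differs from compound 3 by methyl in place of hydrogen on an aromatic carbon, the 4-methylphenyl becoming 2,4-dimethylphenyl. Going by the values given here, no measured pair shows this change on its own, so no step beyond the scatter is expected. For compound 4 the estimate in this assay is 30%, range 15% to 50%, an expected step of a number 4.7 percentage points higher from compound 3 to compound 4 (within the scatter).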

Compound 4, a percentage reported as inhibition, in the whole organism at one dose (the size of the read-out at that dose, not a potency): 27.6%
The estimate for compound 4 lay 2.4 percentage points above the measured number, within the range that was stated.
By their numbers in this assay, from the lowest: compounds 3, 4 and 1 (each within the scatter of the next); then compound 2.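

In this assay, methyl in place of hydrogen on the aromatic carbon, 4-methylphenyl to 2,4-dimethylphenyl, gives a number 2.3 percentage points higher from compound 3 to compound 4 (within the scatter) and so leaves the read-out unresolved from its earlier level. With 2,4-dimethylphenyl held, phenoxymethyl in place of 4-methoxyphenyl gives a number 35.1 percentage points lower from compound 2 to compound 4 (beyond the scatter) and phenoxymethyl in place of 2-chlorophenyl gives a number 5.9 percentage points lower from compound 1 to compound 4 (within the scatter) in the same assay. Only the exchange from 4-methoxyphenyl therefore moves the number beyond the scatter.

Nothing in hand accounts for these steps. Open, on these data alone, is whether an amine or a longer chain at this aromatic carbon would give a different number.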